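Bombesin receptor subtype-3 agonists: tetrazolyl replaced by methylpyridinyl

A few compounds are considered here, and "the series" means these few. Any claim that something is new, unique, unknown or untested is made for them only; others in the source may bear on it.

Measured compounds:
compound 1 `CCC(C)(C)Cc1c[nH]c(CCc2ccc(-n3ncnn3)cc2)n1` — 89 nM
compound 2 `O=C(O)c1cc(F)c(F)cc1-c1ccc(CCc2nc(CC3CCCCC3)c[nH]2)cc1` — 103 nM

In a functional assay on HEK293 cells for agonist activity at Bombesin receptor subtype-3 (Homo sapiens), read by luminescence and calcium flux, with a stated time of 10 min (on this read-out lower numbers stand for an effect already at smaller amounts and higher numbers for an effect only at larger amounts of compound), compound 1 gives 89 nM, the lowest of the two numbers. In this assay compound 2 gives 103 nM, which lies within the scatter of compound 1. Compound 3 `CCC(C)(C)Cc1c[nH]c(CCc2ccc(-c3cccc(C)n3)cc2)n1` differs from compound 1 by 6-methylpyridin-2-yl in place of 2H-tetrazol-2-yl on an aromatic carbon. Among the measured compounds shown here, no measured pair covers this change, so its effect is unknown. The step is expected to be small, a 1.6-fold higher number from compound 1 to compound 3 (0.20 log units; within the scatter), probably not beyond the scatter, with a slight rise judged somewhat more likely than a fall. Compound 3 is estimated at 140 nM, in the range 40 nM to 500 nM.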

Compound 3, half-maximal effective concentration: 102 nM
Compound 3: middle estimate off by 1.4-fold (0.14 log units), on the high side; low and high end bracket the measured number.
By their numbers in this assay, from the lowest: compounds 1, 3 and 2 (each within the scatter of the next).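

In this assay the swap gives a 1.1-fold higher number from compound 1 to compound 3 (0.06 log units; within the scatter), so on this aromatic carbon, para to a large group, a six-membered aromatic ring with 1 hetero atom reads the same as the five-membered aromatic ring with 4 hetero atoms. For this pair, agonist activity at this position does not hang on the 2H-tetrazol-2-yl group. No evidence on this result is at hand. Open, on these data alone, is how a plain phenyl, a pyridin-2-yl without the methyl or a carboxylic acid would read at this position.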